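The source may report more compounds than this note shows. Statements on the series, on what has been measured and on what is new or still open speak of the compounds shown alone.

Compound 1 `CC(C)(C)CC#Cc1cc2ncnc(Nc3ccc(OCc4cccc(F)c4)c(Cl)c3)c2s1` gives 29.3 uM
Compound 2 `Fc1cccc(COc2ccc(Nc3ncnc4cc(C#CCN5CCNCC5)sc34)cc2Cl)c1` gives > 29 uM (a limit)

In an ADME assay on HepG2 cells (Homo sapiens) for cytotoxicity (a higher number here means that more compound is tolerated, a lower number that less compound is tolerated), compound 2 stands at > 29 uM which is a limit of the assay and not a number. Compound 3 `CC(C)(C)OC(=O)N1CCC[C@H]1C#Cc1cc2ncnc(Nc3ccc(OCc4cccc(F)c4)c(Cl)c3)c2s1` differs from it as follows: 1-(tert-butoxycarbonyl)pyrrolidin-2-yl in place of (piperazin-1-yl)methyl on a triple-bonded carbon that is, 1-(tert-butoxycarbonyl)pyrrolidin-2-yl in place of (piperazin-1-yl)methyl on a triple-bonded carbon. Among the compounds with values here, the only measured step (a step that the limit leaves unreadable from compound 1 to compound 2) offers no size to carry over. Within the data shown here, the sole exact reading is compound 1 with 29.3 uM so no step beyond the scatter is expected. The expected step is an at least 1.1-fold lower number from compound 2 to compound 3 (0.06 log units; that floor lies within the scatter) by this estimate. Compound 3 is estimated at 25 uM (expected range 10 uM to 45 uM).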

Compound 3, half-maximal toxic concentration: > 26 uM
Compound 3: no number, only a limit; the forecaster's own chance of this, stated with the estimate: 50%; at least 1.0-fold (0.01 log units) between middle value and limit.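

No step can be read among compound 1, compound 2 and compound 3 in this assay: compound 2 and compound 3 each give a limit of the assay, not a number. As far as these compounds go, whether (piperazin-1-yl)methyl and 1-(tert-butoxycarbonyl)pyrrolidin-2-yl differ in how much compound is tolerated remains open.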